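The source may hold more compounds than are shown below. What is called first, only, known or untested is meant among the compounds shown, and "the series" means these compounds.

Working notes on the series. Compound 3 `COc1ccc(S(=O)(=O)Nc2cc(Cl)cc(Br)c2Cl)cc1N1CCNCC1` gives 2 nM in an assay on isolated protein for binding affinity to 5-hydroxytryptamine receptor 6 (Homo sapiens) (a lower number here means a stronger inhibitor, a higher number a weaker inhibitor), the highest of the three numbers now available. Compound 1 `COc1ccc(S(=O)(=O)Nc2cccc(Br)c2)cc1N1CCNCC1` gives 1.26 nM, and compound 2 `COc1ccc(S(=O)(=O)Nc2cccc(I)c2)cc1N1CCNCC1` gives 0.501 nM. The steps of a 1.6-fold higher number from compound 1 to compound 3 (0.20 log units; within the scatter) and a 4.0-fold higher number from compound 2 to compound 3 (0.60 log units; beyond the scatter) place compound 3 where it stands; only the second of them lies beyond the scatter. Among the compounds with values here, the one swap of halogen for halogen measured so far is a 2.5-fold lower number from compound 1 to compound 2 (0.40 log units; beyond the scatter).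

Compound 4 `COc1ccc(S(=O)(=O)Nc2cc(Br)cc(F)c2Cl)cc1N1CCNCC1` has not yet been measured in this assay. It differs from compound 3 in one place: 5-bromo-2-chloro-3-fluorophenyl in place of 3-bromo-2,5-dichlorophenyl on a sulfonamide nitrogen. Within the data shown here, no measured step exchanges one halogen for another on this ring while the other two remain, so the nearest guides are the halogen swap a 2.5-fold lower number from compound 1 to compound 2 (0.40 log units; beyond the scatter) and the two steps that build up the trihalophenyl, a 1.6-fold higher number from compound 1 to compound 3 (0.20 log units; within the scatter) and a 4.0-fold higher number from compound 2 to compound 3 (0.60 log units; beyond the scatter), all of them modest at most. A step no larger than the scatter is therefore expected, a 1.3-fold higher number from compound 3 to compound 4 (0.10 log units; within the scatter), with no firm direction. Compound 4 is estimated at 2.5 nM, within 1 nM to 6.3 nM.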

Compound 4, inhibition constant: 3.16 nM
Compound 4: the middle estimate sits 1.3-fold (0.10 log units) below what was measured; the measured number falls inside the stated range.
By their numbers in this assay, from the lowest: compound 2; then compounds 1, 3 and 4 (each within the scatter of the next, the first and the last beyond it).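

In this assay, within the data shown here, the exchange of 3-bromo-2,5-dichlorophenyl for 5-bromo-2-chloro-3-fluorophenyl on a sulfonamide nitrogen, the first swap of one halogen for another on a trihalophenyl, gives no readable change (a 1.6-fold higher number from compound 3 to compound 4 (0.20 log units; within the scatter)). Set against the singly substituted rings, compound 4 stands clear of the scatter on both steps (a 2.5-fold higher number from compound 1 to compound 4 (0.40 log units; beyond the scatter); a 6.3-fold higher number from compound 2 to compound 4 (0.80 log units; beyond the scatter)), both modest. Compound 3 had done so only against compound 2, so the fluorine-bearing ring separates from 3-bromophenyl where the dichloro ring did not.

As far as these compounds go, whether a methoxy group, a nitrile or an amine in place of the fluorine would keep a number of this order remains open. Nothing available bears on the reason for these steps.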